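Cytotoxicity of three aryl analogues and a nitrophenyl variant

This account rests on a few compounds, and the source may have more. Where it says the series, first, only, none or still open, it means among the compounds named here.

Measured compounds:
compound 1 `N#Cc1c(-c2ccc(Cl)cc2)c(C#N)c(=O)n(/N=C/c2cn(-c3ccccc3)nc2-c2ccccc2)c1N`: 64 ug/mL
compound 2 `Cc1ccc(-c2c(C#N)c(N)n(/N=C/c3cn(-c4ccccc4)nc3-c3ccccc3)c(=O)c2C#N)cc1`: 98 ug/mL
compound 3 `COc1ccc(-c2c(C#N)c(N)n(/N=C/c3cn(-c4ccccc4)nc3-c3ccccc3)c(=O)c2C#N)cc1`: 50 ug/mL

In an ADME assay on NIH3T3 cells (Mus musculus) for cytotoxicity, read by MTT assay (on this read-out lower numbers stand for stronger inhibition and higher numbers for weaker inhibition), compound 1 gives 64 ug/mL, the second highest of the three numbers. Compound 3 gives 50 ug/mL and compound 2 gives 98 ug/mL, and every step among the three stays within the scatter. Compound 4 `N#Cc1c(-c2ccccc2[N+](=O)[O-])c(C#N)c(=O)n(/N=C/c2cn(-c3ccccc3)nc2-c2ccccc2)c1N` differs from compound 1 by 2-nitrophenyl in place of 4-chlorophenyl on an aromatic carbon. Going by the values given here, no measured step involves a nitro group; the steps that exchange the same aromatic substituent, a 1.5-fold higher number from compound 1 to compound 2 (0.19 log units; within the scatter), a 1.3-fold lower number from compound 1 to compound 3 (0.11 log units; within the scatter) and a 2.0-fold lower number from compound 2 to compound 3 (0.29 log units; within the scatter), all lie within the scatter. The step to compound 4 is therefore expected to stay within the scatter too, in no particular direction, which is a 1.0-fold higher number from compound 1 to compound 4 (0.01 log units; within the scatter). For compound 4 the estimate is 65 ug/mL, with a range from 30 ug/mL to 130 ug/mL.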

Compound 4, half-maximal inhibitory concentration: > 200 ug/mL
Compound 4: no number, only a limit; the forecaster's own chance of this, stated with the estimate: 15%; middle value at least 3.0-fold (0.48 log units) away from the limit.
By their numbers in this assay, from the lowest: compounds 3, 1 and 2 (each within the scatter of the next). At a limit, above all of these: compound 4.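

Going by these compounds alone, at this position, opposite the ring nitrogen, 2-nitrophenyl gives the first change that clears the scatter, with an at least 3.1-fold higher number from compound 1 to compound 4 (0.49 log units; beyond the scatter) and an at least 4.0-fold higher number from compound 3 to compound 4 (0.60 log units; beyond the scatter). The comparison with 4-methylphenyl is less firm, with an at least 2.0-fold higher number from compound 2 to compound 4 (0.30 log units; that floor lies within the scatter). In this assay, compound 4 gives a limit and not a number: the limit of > 200 ug/mL in this assay, at which 1 of the 4 values shown sits.

The compounds shown leave open whether this change follows the nitro group itself or its place on the phenyl ring. They also leave open whether an amine or a carboxylic acid on that ring would reach such a limit.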